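Methyl for methoxy on the aryl ring: expected outcome

A few compounds are considered here, and "the series" means these few. Any claim that something is new, unique, unknown or untested is made for them only; others in the source may bear on it.

Measured so far:
compound 1 `COc1ccccc1N1CCn2c1n[nH]c(=O)c2=O` — 1%
compound 2 `N=c1c(=O)[nH]nc2n1CCN2c1ccc(Cl)cc1` — 16%

In a functional assay on T47D cells (Homo sapiens) for cytotoxicity, with a stated time of 72 h, tested at 10 ug/mL (on this read-out lower numbers stand for a weaker effect and higher numbers for a stronger effect at the one concentration tested), compound 1 gives 1%, the lowest of the two numbers at hand. Compound 2 gives 16%, which lies higher by a margin beyond the usual scatter; the two compounds differ in more than one place, so their gap tells nothing about any single change.

Compound 3 `Cc1ccccc1N1CCn2c1n[nH]c(=O)c2=O` differs from compound 1 in one place: methyl in place of methoxy on an aromatic carbon. Going by the values given here, no pair of measured compounds differing in one place exists, so no measured step guides this change. With compound 1 at 1% and nothing to suggest a large move, the expected step of a number 3 percentage points higher from compound 1 to compound 3 (within the scatter) is one of no change beyond the scatter. Compound 3 is therefore estimated at 4% in this assay, with a range from 0% to 18%.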

Compound 3, a percentage reported as inhibition, at one concentration (the size of the read-out at that concentration, not a potency): 0%
Estimate against measurement, compound 3: 4 percentage points above; measured number inside the range.
By their numbers in this assay, from the lowest: compounds 3 and 1 (each within the scatter of the next); then compound 2.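

In this assay, going by these compounds alone, the first single-place change gives a number 1 percentage points lower from compound 1 to compound 3 (within the scatter), so methyl in place of methoxy on this aromatic carbon, ortho to a large group, does not separate the two compounds. With both numbers this close to zero, the pair could show a gain at this position but hardly a loss, and no gain beyond the scatter appears. Nothing measured here speaks to a cause for this result.

Open, from the compounds shown here alone, is whether an amine, a carboxylic acid or a longer chain such as ethoxy at this same place would lift the number clear of the scatter. Also open, going by these compounds, is whether methyl in place of methoxy would leave the number unchanged on a compound starting high enough for a loss to be read.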